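The source may hold more compounds than are shown below. What is called first, only, known or untested is meant among the compounds shown, and "the series" means these compounds.

Going by the values given here, in an ADME assay on Vero cells (Chlorocebus sabaeus) for cytotoxicity, read by CellTiter-Glo, with a stated time of 72 h (on this read-out higher numbers stand for lower toxicity in this test and lower numbers for higher toxicity in this test), compound 1 `[O-][n+]1nc(NC2CCC2)[n+]([O-])c2ccc(F)cc21` gives 1.6 ug/mL, the lower of the two exact numbers available so far. Compound 3 `COCC(C)Nc1n[n+]([O-])c2cc(F)ccc2[n+]1[O-]` gives 6.3 ug/mL. Compound 2 `[O-][n+]1nc(NC2CCCCC2)[n+]([O-])c2ccc(F)cc21` is reported only as a limit, < 2.5 ug/mL. Cyclohexyl in place of cyclobutyl on the nitrogen gives a step that the limit leaves unreadable from compound 1 to compound 2. 1-(Methoxymethyl)ethyl in place of cyclobutyl gives a 3.9-fold higher number from compound 1 to compound 3 (0.60 log units; beyond the scatter), and the same group in place of cyclohexyl gives an at least 2.5-fold higher number from compound 2 to compound 3 (0.40 log units; beyond the scatter).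

Compound 4 `COc1ccc2c(c1)[n+]([O-])nc(NC1CCC1)[n+]2[O-]` keeps the cyclobutyl group of compound 1 and differs elsewhere: methoxy in place of fluoro on an aromatic carbon. Among the compounds with values here, all the measured steps change the group on the nitrogen, and none touches the fluoro, so they bear on this change only indirectly. They show modest movement in this assay within this small set, so no step beyond the scatter is expected, with a slight lean towards a higher number. The expected change is a 1.6-fold higher number from compound 1 to compound 4 (0.19 log units; within the scatter). For compound 4 the estimated value is 2.5 ug/mL, with an expected range from 1 ug/mL to 6.5 ug/mL.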

Compound 4, half-maximal cytotoxic concentration: 9.8 ug/mL
Estimate against measurement, compound 4: 3.9-fold (0.59 log units) below, outside the stated range (above it).
By their numbers in this assay, from the lowest: compound 1; then compounds 3 and 4 (each within the scatter of the next).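

In this assay, methoxy in place of fluoro on an aromatic carbon gives a 6.1-fold higher number from compound 1 to compound 4 (0.79 log units; beyond the scatter) with the cyclobutyl group on the nitrogen kept the same. This is the first change shown away from the group on the nitrogen, and it shows that the read-out also responds to this aromatic carbon. Nothing measured here for fluoro or methoxy accounts for the size of this step.

On these data alone, it remains open whether the same change would move the number by a similar amount with cyclohexyl or 1-(methoxymethyl)ethyl on the nitrogen. Also open, as far as these compounds go, is how chloro, hydroxy, an amine or a longer alkoxy chain would read on this carbon, and whether plain hydrogen there would separate the loss of fluoro from the arrival of methoxy.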